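A Trifluoromethyl Ketone Replaces the Pyridine on the Oxazole

A few compounds are considered here, and "the series" means these few. Any claim that something is new, unique, unknown or untested is made for them only; others in the source may bear on it.

Of the compounds shown here, three that share one core have been measured in an assay (Rattus norvegicus) for inhibition of Fatty-acid amide hydrolase 1 (Homo sapiens); on this read-out higher numbers stand for weaker inhibition and lower numbers for stronger inhibition. Compound 1 `N#Cc1ccc(-c2cnc(C(=O)CCCCCCc3ccccc3)o2)cc1` gives 40 nM. Compound 2 `Cc1cccnc1-c1cnc(C(=O)CCCCCCc2ccccc2)o1` gives 15 nM, and compound 3 `COC(=O)c1ccc(-c2cnc(C(=O)CCCCCCc3ccccc3)o2)nc1` gives 3.5 nM. Compound 2 therefore stands second highest of the three numbers: the nearest is compound 1, with a higher number, and the furthest is compound 3, with a lower number; both gaps lie beyond the scatter.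

For the measured compounds named here, the one step available between compounds that differ in a single place is a 2.7-fold lower number from compound 1 to compound 2 (0.43 log units; beyond the scatter), a modest move. Compound 4 `O=C(CCCCCCc1ccccc1)c1ncc(C(=O)C(F)(F)F)o1` has not yet been measured. It differs from compound 2 as follows: (trifluoromethyl)carbonyl in place of 3-methylpyridin-2-yl on an aromatic carbon. Going by the values given here, no measured step changes the group at this place of the core for a group without a ring, so the step from compound 1 to compound 2 bears on it only loosely, as the one example of swapping groups at that position, and compound 3 shows only that a lower number is reachable on this core. On that thin basis he expects the number for compound 4 to move modestly downward, a 3.0-fold lower number from compound 2 to compound 4 (0.48 log units; beyond the scatter), with a wide range. His estimate for compound 4 in this assay is 5 nM, between 1 nM and 25 nM.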

Compound 4, inhibition constant: 4 nM
Estimate against measurement, compound 4: 1.3-fold (0.10 log units) above; the measured number falls inside the stated range.
By their numbers in this assay, from the lowest: compounds 3 and 4 (each within the scatter of the next); then compound 2; then compound 1.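

The result shows that this position does not need a ring: every earlier compound carried a six-membered aromatic ring on this aromatic carbon, whereas (trifluoromethyl)carbonyl has no ring and still gives a 3.8-fold lower number from compound 2 to compound 4 (0.57 log units; beyond the scatter) in this assay, and, measured against the 4-cyanophenyl group, a 10-fold lower number from compound 1 to compound 4 (1.00 log units; beyond the scatter). Compound 4 at 4 nM and compound 3 at 3.5 nM lie within the scatter of each other, so a ring-free group on this carbon reaches the same level as the best ring-bearing group shown, and the low numbers on this core are not confined to one kind of group. Nothing available explains why this exchange moves the number as it does.

On these data alone, whether an acetyl group or a trifluoromethyl group alone on this carbon would give a number like that of compound 4 stays open, which leaves the share of the carbonyl and of the fluorines unsettled, and the outcome for an amine or a carboxylic acid there is equally open. Also open, as far as these compounds go, is whether the same exchange would hold with a shorter chain on the ring atom that bears the large group.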